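Chromone ethers with basic side chains: sigma binding notes

A few compounds are considered here, and "the series" means these few. Any claim that something is new, unique, unknown or untested is made for them only; others in the source may bear on it.

Measured so far:
compound 1 `CN(C)CCCCCCCCCOc1ccc2oc(-c3ccccc3)cc(=O)c2c1` — 334 nM
compound 2 `O=c1cc(-c2ccccc2)oc2ccc(OCCCCCCN3CCC(O)CC3)cc12` — 100 nM

In an assay on isolated protein (Cavia porcellus) with Sigma non-opioid intracellular receptor 1 (Homo sapiens) as the target, read by radioligand binding (a lower number here means a stronger inhibitor, a higher number a weaker inhibitor), compound 2 gives 100 nM, the lowest of the two numbers; compound 1 stands higher by a 3.3-fold lower number from compound 1 to compound 2 (0.52 log units; beyond the scatter). Compound 3 `NCCCCCCOc1ccc2oc(-c3ccccc3)cc(=O)c2c1` is not yet measured. Its change from compound 2: amino in place of 4-hydroxypiperidin-1-yl on a saturated chain carbon, six bonds along the chain from an oxygen on an aromatic ring. For the measured compounds named here, the only step measured, a 3.3-fold lower number from compound 1 to compound 2 (0.52 log units; beyond the scatter), exchanges one chain-end nitrogen group for another and is modest. Compound 3 drops the ring entirely for a bare amino, a larger change; the expectation is a weakening, with an expected step of an 8.0-fold higher number from compound 2 to compound 3 (0.90 log units; beyond the scatter). For compound 3 the estimate is 800 nM, in the range 200 nM to 3000 nM.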

Compound 3, half-maximal inhibitory concentration: 2100 nM
Estimate against measurement, compound 3: 2.6-fold (0.42 log units) below, and the stated range covers the measured number.
By their numbers in this assay, from the lowest: compound 2; then compound 1; then compound 3.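

In this assay, for the compounds shown here, the group at the chain end counts for more than the one earlier step showed: a 21-fold higher number from compound 2 to compound 3 (1.32 log units; beyond the scatter) comes with amino replacing 4-hydroxypiperidin-1-yl, and a 6.3-fold higher number from compound 1 to compound 3 (0.80 log units; beyond the scatter) comes with amino replacing 3-(dimethylamino)propyl. Among the three compounds, the bare amino end gives the highest number, so it does not match either larger nitrogen group. Nothing on hand accounts for this loss.

Open, from the compounds shown here alone, is where between amino and the larger groups the number falls, for instance with a methylamino or dimethylamino end on the same chain. Also open, going by these compounds, is whether a plain piperidin-1-yl, without the hydroxyl, matches 4-hydroxypiperidin-1-yl.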